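The compounds below may be only part of what the source reports. "The series", "measured", "known", "first", "only" and "open" are said of these compounds alone.

In an assay on isolated protein for inhibition of myosin-2 (Bos taurus), read by spectrophotometry, with a stated time of 24 min (a lower number here means a stronger inhibitor, a higher number a weaker inhibitor), the three measured compounds stand as follows:

Compound 1 `C/C(=N\C(C)C)c1c(O)c2ccccc2[nH]c1=O` gives >= 100000 nM, a limit of the assay.
Compound 2 `CCC(C)/N=C(\C)c1c(O)c2ccccc2[nH]c1=O` gives >= 100000 nM, a limit of the assay.
Compound 3 `CCC/C(=N\Cc1ccccc1)c1c(O)c2ccccc2oc1=O` gives >= 100000 nM, a limit of the assay.

None of the three readings is a number, and the limit of >= 100000 nM in this assay, at which 3 of the 3 values shown sit, is all that is known. Compound 2 and compound 1 differ by hydrogen in place of methyl on a saturated chain carbon, two bonds along the chain from a double-bonded nitrogen and the step that the two limits leave unreadable from compound 2 to compound 1. The difference between the core of compound 3 and the core of compound 2 is not broken down here. Compound 4 `CC/C(=N\Cc1ccccc1)c1c(O)c2ccccc2oc1=O` is to be measured in this assay; it differs from compound 3 by hydrogen in place of methyl on a saturated chain carbon, two bonds along the chain from a carbon with a double bond to nitrogen, the same kind of change, the place being two bonds along the chain from a carbon with a double bond to nitrogen rather than from a double-bonded nitrogen. The step from compound 3 to compound 4 is expected to be a number no higher from compound 3 to compound 4 (the limit leaves the size open) because the limit of >= 100000 nM in this assay, at which 3 of the 3 values shown sit, and because the like step that the two limits leave unreadable from compound 2 to compound 1. Compound 4 is therefore estimated at 100000 nM, between 40000 nM and 300000 nM.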

Compound 4, half-maximal inhibitory concentration: >= 100000 nM
Compound 4: only a limit was reported; the forecaster's own chance of this, stated with the estimate: 85%; the middle value sits exactly at the limit.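

In this assay, going by these compounds alone, compound 3 and compound 4 both rest on limits of the assay, so no step between them can be read. The compounds shown leave open how strongly any of them inhibits, and the only reading is a shared one: the limit of >= 100000 nM in this assay, at which 4 of the 4 values shown sit.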